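The source may report more compounds than this note shows. Statements on the series, on what has been measured and on what is new or still open speak of the compounds shown alone.

Within the data shown here, in a functional assay on HeLa cells (Homo sapiens) for inhibition, read by CCK-8 assay, with a stated time of 72 h, tested at 8 uM (a higher number here means more inhibition of growth at the concentration tested, a lower number less inhibition of growth), compound 1 (`Nc1ccccc1NC(=O)/C=C/c1ccc(CSc2cccc(F)c2)cc1`) gives 18.6% and stands lowest of the two numbers so far. Compound 2 (`Nc1ccccc1NC(=O)c1ccc(CSc2cccc(F)c2)cc1`) gives 78.4% with the gap beyond the scatter. Compound 3 (`CC(C)(C)c1ccc(SCc2ccc(/C=C/C(=O)Nc3ccccc3N)cc2)cc1`) carries 4-(tert-butyl)phenyl in place of 3-fluorophenyl on a sulfur. Among the measured compounds shown here, no measured pair shows this change, so the expectation rests on compound 1 at 18.6% alone. In this assay the estimated step of a number 1.4 percentage points higher from compound 1 to compound 3 (within the scatter) is expected to stay within the scatter, with no firm direction. For compound 3 the estimated value is 20% with an expected range from 5% to 40% at this stage.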

Compound 3, percent growth inhibition at one concentration: 9.8%
Compound 3: the middle estimate sits 10.2 percentage points above what was measured; the measured number falls inside the stated range.
By their numbers in this assay, from the lowest: compounds 3 and 1 (each within the scatter of the next); then compound 2.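

In this assay, 4-(tert-butyl)phenyl in place of 3-fluorophenyl on a sulfur gives a number 8.8 percentage points lower from compound 1 to compound 3 (within the scatter), the only reading at this position among the compounds shown. This position therefore takes this exchange of one carbon-only aromatic ring group for another without a change beyond the scatter. No measurement at hand explains the result.

From the compounds shown here alone, it remains open whether an amine or a carboxylic acid on this sulfur would move the number. Also open, going by these compounds, is whether the same exchange would hold on the core of compound 2.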